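This account rests on a few compounds, and the source may have more. Where it says the series, first, only, none or still open, it means among the compounds named here.

Measured in an ADME assay on MT4 cells (Homo sapiens) for cytotoxicity, read by MTT assay, with a stated time of 5 days; a lower number here means that less compound is tolerated, a higher number that more compound is tolerated:
- compound 1 `Cc1cc(C)cc(Oc2cc(Nc3ccc(C#N)cc3)[nH]c(=O)c2Cl)c1`: 21000 nM
- compound 2 `Cc1cc(C)c(Oc2cc(Nc3ccc(C#N)cc3)[nH]c(=O)c2Br)c(C)c1`: > 294000 nM

Compound 2 gives > 294000 nM, which is a limit of the assay and not a number. Going by the values given here, its true place is therefore unknown, and compound 1, at 21000 nM, supplies the only exact number so far.

Compound 3 `Cc1cc(C)cc(Oc2cc(Nc3ccc(C#N)cc3)[nH]c(=O)c2Br)c1` has not yet been measured. It differs from compound 2 in one place: 3,5-dimethylphenyl in place of 2,4,6-trimethylphenyl on an oxygen on an aromatic ring. In words, 3,5-dimethylphenyl stands in place of 2,4,6-trimethylphenyl on an oxygen on an aromatic ring. Among the compounds with values here, no measured pair shows this change directly, so the expectation leans on compound 1 at 21000 nM, whose structure is the closest guide. A large downward move beyond the scatter is expected, meaning that less compound would be tolerated: an at least 11-fold lower number from compound 2 to compound 3 (1.07 log units; beyond the scatter). For compound 3 the expected value is 25000 nM, with an estimated range of 10000 nM to 70000 nM.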

Compound 3, half-maximal cytotoxic concentration: 19000 nM
Estimate against measurement, compound 3: 1.3-fold (0.12 log units) above; the measured number falls inside the stated range.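

In this assay, going by these compounds alone, 3,5-dimethylphenyl in place of 2,4,6-trimethylphenyl on the oxygen gives an at least 15-fold lower number from compound 2 to compound 3 (1.18 log units; beyond the scatter), the first direct reading of this change, with the bromo group held constant. The entry for compound 2 is a limit of the assay and not a number, so the true size of this step stays unknown: the limit of > 294000 nM in this assay, at which 1 of the 3 values shown sits.

With 3,5-dimethylphenyl on the oxygen, bromo in place of chloro on an aromatic carbon gives a 1.1-fold lower number from compound 1 to compound 3 (0.04 log units; within the scatter), so these two halogens cannot be told apart in this assay.

As far as these compounds go, whether chloro together with 2,4,6-trimethylphenyl would behave like compound 2 remains open. Also open, from the compounds shown here alone, is what a plain phenyl on the oxygen, or an amine on the aromatic carbon that carries the halogen, would give.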